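The compounds below may be only part of what the source reports. "The series", "measured", "known", "first", "only" and "open" are said of these compounds alone.

The three measured compounds share one core and differ only in the aryl group that sits on an amide-type nitrogen in a ring. Compound 1 `COc1ccc(C)cc1N1C(=O)CSC1c1cccc(C(=O)NCCCCc2ccccc2)c1` carries a 2-methoxy-5-methylphenyl there, compound 2 `COc1cc(F)ccc1N1C(=O)CSC1c1cccc(C(=O)NCCCCc2ccccc2)c1` a 4-fluoro-2-methoxyphenyl and compound 3 `O=C(NCCCCc1ccccc1)c1cccc(C2SCC(=O)N2c2cccc(F)c2)c1` a 3-fluorophenyl. In a functional assay on HOS-TE85 cells (Homo sapiens) for inhibition, read by CCK-8 assay, with a stated time of 72 h, tested at 1 uM (on this read-out lower numbers stand for less inhibition and higher numbers for more inhibition at the one concentration tested (going by the name of the read-out)), compound 1 gives 95%, compound 2 gives 94% and compound 3 gives 94%. Compound 3 thus stands level with compound 2 at the digits shown, the two together being the lowest of the three numbers, while all three lie within the scatter of one another: no change at the digits printed from compound 2 to compound 3 (within the scatter) and a number 1 percentage points lower from compound 1 to compound 3 (within the scatter).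

The change to compound 4 `COc1cccc(OC)c1N1C(=O)CSC1c1cccc(C(=O)NCCCCc2ccccc2)c1` is 2,6-dimethoxyphenyl in place of 3-fluorophenyl on an amide-type nitrogen in a ring. Among the compounds with values here, the steps that bear on it are the three that also swap the aryl group on that nitrogen: a number 1 percentage points lower from compound 1 to compound 2 (within the scatter), a number 1 percentage points lower from compound 1 to compound 3 (within the scatter) and no change at the digits printed from compound 2 to compound 3 (within the scatter), none of which moved the read-out beyond the scatter. Within the data shown here, no measured compound carries a 2,6-dimethoxyphenyl, so the expectation is held somewhat wider. The step expected in this assay from compound 3 to compound 4 is a number 3 percentage points lower from compound 3 to compound 4 (within the scatter), that is, none beyond the scatter. Compound 4 is therefore estimated at 91%, with a range from 72% to 98%.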

Compound 4, a percentage reported as inhibition, at one concentration (the size of the read-out at that concentration, not a potency): 95%
The estimate for compound 4 lay 4 percentage points below the measured number; the measured number falls inside the stated range.
By their numbers in this assay, from the lowest: compounds 2, 3, 1 and 4 (each within the scatter of the next).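

In this assay, the 2,6-dimethoxyphenyl, with 10 heavy atoms and 2 hydrogen-bond acceptors, takes the place of the 3-fluorophenyl, with 7 heavy atoms and 0 hydrogen-bond acceptors, and the result is a number 1 percentage points higher from compound 3 to compound 4 (within the scatter); the comparisons with the other two aryl groups give a number 1 percentage points higher from compound 2 to compound 4 (within the scatter) and no change at the digits printed from compound 1 to compound 4 (within the scatter). The earlier compounds shown here carried no more than one methoxy group on this aryl ring, so the new result extends the flat picture at this amide-type nitrogen to a second methoxy group, and all four compounds remain within the scatter of one another at the single concentration tested. Nothing available offers an explanation for this flat result.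

On these data alone, it remains open whether a carboxylic acid or a dimethylamino group on this aryl ring, or a simple butyl chain in place of the aryl ring on this nitrogen, would move the read-out beyond the scatter. Also open, as far as these compounds go, is whether these four compounds, which this read-out does not separate, would differ from one another at lower concentrations.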